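Swapping Fluoro for Chloro in a Small Antiproliferative Series

The source may hold more compounds than are shown below. What is called first, only, known or untested is meant among the compounds shown, and "the series" means these compounds.

In a functional assay on A549 cells (Homo sapiens) for antiproliferative activity, read by MTT assay, with a stated time of 48 h (a higher number here means a weaker inhibitor, a lower number a stronger inhibitor), compound 1 `COc1ccc(N(C)c2cc(C)nc(C)n2)cc1` gives 277 nM, while compound 2 `COc1ccc(N(C)c2cc(C)nc(C)n2)cc1F` gives 632 nM, the higher of the two numbers. Compound 3 `COc1ccc(N(C)c2cc(C)nc(C)n2)cc1Cl` departs from compound 2 by one change: chloro in place of fluoro on an aromatic carbon. Within the data shown here, the only measured step that bears on it is a 2.3-fold higher number from compound 1 to compound 2 (0.36 log units; beyond the scatter), a modest one that replaced hydrogen with fluoro on an aromatic carbon. Among the measured compounds shown here, no chloro compound has been measured, so the direction remains open and no step beyond the scatter is expected. The expected step is a 1.1-fold lower number from compound 2 to compound 3 (0.02 log units; within the scatter). For compound 3 the estimated value is 600 nM, with an expected range from 250 nM to 1400 nM.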

Compound 3, half-maximal inhibitory concentration: 780 nM
Compound 3: the middle estimate sits 1.3-fold (0.11 log units) below what was measured, and the stated range covers the measured number.
By their numbers in this assay, from the lowest: compound 1; then compounds 2 and 3 (each within the scatter of the next).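

At this position, ortho to a methoxy group, exchanging fluoro for chloro gives a 1.2-fold higher number from compound 2 to compound 3 (0.09 log units; within the scatter) in this assay, so the two halogens are not separated here. Chloro in place of hydrogen gives a 2.8-fold higher number from compound 1 to compound 3 (0.45 log units; beyond the scatter) as well, which shows that the rise seen with fluoro is not confined to that one halogen. No measurement shown gives an explanation for this result. Still open, going by these compounds, is whether a group other than a halogen at this position, such as an amine or a nitrile, would match or lower the number of compound 1.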